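The source may report more compounds than this note shows. Statements on the series, on what has been measured and on what is new or still open speak of the compounds shown alone.

Working notes on the series, read in an ADME assay on SH-SY5Y cells (Homo sapiens) for cytotoxicity, read by MTT assay, with a stated time of 72 h; on this read-out higher numbers stand for weaker inhibition and lower numbers for stronger inhibition. Compound 1 `Cc1ccc(C(=O)N2CCN(CC(=O)N3CCN(CCCc4c[nH]c5ccccc45)CC3)CC2)cc1` gives > 200000 nM, which is a limit of the assay and not a number. Within the data shown here, compound 2 `COc1ccc2[nH]cc(CCCN3CCN(C(=O)CN4CCN(C(=O)c5ccc(Br)cc5)CC4)CC3)c2c1` gives 150000 nM, the only actual number so far. Compound 3 `COc1ccc2[nH]cc(CCCN3CCN(C(=O)CN4CCN(C(=O)c5ccc(C)cc5)CC4)CC3)c2c1` is still unmeasured and departs from compound 2 by one change: methyl in place of bromo on an aromatic carbon. No measured step sizes this change, so nothing beyond the scatter is expected in this assay. The estimated step is a 1.1-fold higher number from compound 2 to compound 3 (0.03 log units; within the scatter). For compound 3 the expected value is 160000 nM, with an estimated range of 90000 nM to 200000 nM.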

Compound 3, half-maximal inhibitory concentration: > 200000 nM
Compound 3: no number, only a limit; the forecaster's own chance of this, stated with the estimate: 35%; at least 1.2-fold (0.09 log units) between middle value and limit.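

In this assay, among these compounds, the change from bromo to methyl, on an aromatic carbon para to a large group, gives an at least 1.3-fold higher number from compound 2 to compound 3 (0.12 log units; that floor lies within the scatter) and is the first step that can be sized at all. The step between the two limit compounds, compound 1 and compound 3, cannot be read. The size of the bromo to methyl change stays a floor because compound 3 sits at a limit of the assay: the limit of > 200000 nM in this assay, at which 2 of the 3 values shown sit.

As far as these compounds go, what an amine or a carboxylic acid on this aromatic carbon would give remains open. So does whether any group here reaches a number well below that of compound 2.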